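The source may report more compounds than this note shows. Statements on the series, on what has been measured and on what is new or still open speak of the compounds shown alone.

Four compounds sharing one core are compared in a functional assay on the whole organism for inhibition, with Rattus norvegicus as the target; on this read-out lower numbers stand for an effect already at smaller amounts and higher numbers for an effect only at larger amounts of compound. Compound 1, `CC1CC/C(=N\Nc2ccccc2I)c2ncc(C(=O)O)c(=O)n21`, reaches only the limit of this assay, giving > 1000 umol/kg and no number. Compound 2, `CC1CC/C(=N\Nc2cccc(I)c2)c2ncc(C(=O)O)c(=O)n21`, differs from compound 1 in that (3-iodophenyl in place of 2-iodophenyl on an amine nitrogen), and in this assay compound 2 gives 1000 umol/kg. The step is a number no higher from compound 1 to compound 2 (the limit leaves the size open). Compound 3, `CCOc1ccccc1N/N=C1\CCC(C)n2c1ncc(C(=O)O)c2=O`, carries ethoxy in place of iodo on an aromatic carbon; in this assay compound 3 also returns only a limit, > 1000 umol/kg. Accordingly the step that the two limits leave unreadable from compound 1 to compound 3 cannot be sized. The whole picture is shaped by the limit of > 1000 umol/kg in this assay, at which 2 of the 3 values shown sit, so that only compound 2 supplies a number.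

Compound 4, `CCOc1cccc(N/N=C2\CCC(C)n3c2ncc(C(=O)O)c3=O)c1`, is not yet measured. Relative to compound 2 it carries ethoxy in place of iodo on an aromatic carbon. This is the same kind of change as that made from compound 1 to compound 3, yet the place differs: there the entering ethoxy sits ortho to a large group, here it sits meta to a large group. The earlier instance of the change left no readable size. For compound 4 an expected value of 1500 umol/kg in this assay is therefore tentative, with an estimated range from 500 umol/kg to 5000 umol/kg. The expected step is a 1.5-fold higher number from compound 2 to compound 4 (0.18 log units; within the scatter), resting on compound 2 at 1000 umol/kg and on the unreadable size of a step that the two limits leave unreadable from compound 1 to compound 3.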

Compound 4, dose for 50% inhibition: > 1000 umol/kg
Compound 4: only a limit was reported (the forecaster's own chance of this, stated with the estimate: 60%); the middle value lies beyond the limit too.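

In this assay, ethoxy in place of iodo, meta to a large group, gives a number no lower from compound 2 to compound 4 (the limit leaves the size open), and compound 4 returns only a limit, not a number. The same exchange on the other iodo compound also ended at a limit, so neither instance of the change has a readable size, and the two cannot be compared with each other. The new step shows only that, on the core arrangement of compound 2, ethoxy brought no lower number; it does not show how large the step is, or whether the change behaves alike in both places, and the whole comparison stays tied to one boundary: the limit of > 1000 umol/kg in this assay, at which 3 of the 4 values shown sit.

The compounds shown leave open whether any other group in the place of iodo, such as methoxy, a longer chain such as butoxy, or an amine, would give a readable number in this assay. They also leave open how the series would read with an amide in the place of the carboxylic acid, as every compound shown carries that acid.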